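The source may hold more compounds than are shown below. What is called first, only, known or untested is meant among the compounds shown, and "the series" means these compounds.

Measured so far in a functional assay on the whole organism for agonist activity, with Mus musculus as the target (on this read-out lower numbers stand for an effect already at smaller amounts and higher numbers for an effect only at larger amounts of compound), for the series:
- compound 1 `CC(C#CCN(C)C)N1CCCC1=O` gives 100 mg/kg as a number
- compound 2 `Cc1cncn1CC#CCN1C(=O)CCC1C` gives > 100 mg/kg as a limit
- compound 3 `CC(=O)NCC#CCn1ccnc1` gives > 100 mg/kg as a limit

Compound 3 stands at > 100 mg/kg and this is a limit of the assay, not a number. It shares that position with one other compound of the three (the limit of > 100 mg/kg in this assay, at which 2 of the 3 values shown sit). Compound 4 `CC(=O)NCC#CCn1cncc1C` is the next analogue to be read. It departs from compound 3 in one place only (methyl in place of hydrogen on an aromatic carbon), with methyl in place of hydrogen on an aromatic carbon.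

For the measured compounds named here, no measured pair differs in a single place, so the size of this change cannot be read directly. The closest guide is compound 2, which also carries methyl on an aromatic carbon and gives > 100 mg/kg as a limit. On that basis, no shift beyond the usual scatter is expected, and the estimated move is small (a step that the limit leaves unreadable from compound 3 to compound 4). A reading at the limit again is the likeliest outcome in this assay. For compound 4 the expected value is 150 mg/kg with an estimated range from 70 mg/kg to 300 mg/kg (an expectation only).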

Compound 4, dose for half-maximal effect: > 100 mg/kg
Compound 4 was reported as a limit; the forecaster's own chance of this, stated with the estimate: 80%; the middle value does not contradict the limit.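

No step can be read from compound 3 to compound 4 in this assay, as both are reported only as a limit of the assay and not as a number: the limit of > 100 mg/kg in this assay, at which 3 of the 4 values shown sit.

The compounds shown leave open whether methyl in place of hydrogen on an aromatic carbon changes the read-out at all, and in which direction.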